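Halogen swap on the amide aryl of the naphthyl series

This account rests on a few compounds, and the source may have more. Where it says the series, first, only, none or still open, it means among the compounds named here.

Measured so far:
- Compound 1 `O=C(Nc1c(C(O)(C(F)(F)F)C(F)(F)F)ccc2ccccc12)c1ccccc1Cl`: in an assay on LtK cells with ATP-sensitive inward rectifier potassium channel 11 (Homo sapiens) as the target (on this read-out lower numbers stand for an effect already at smaller amounts and higher numbers for an effect only at larger amounts of compound), compound 1 gives 2040 nM
- Compound 2 `O=C(Nc1c(C(O)(C(F)(F)F)C(F)(F)F)ccc2ccccc12)c1cccc(Br)c1`: in this assay compound 2 gives 80 nM

Compound 2 stands lowest of the two numbers shown. Within the data shown here, the single measured step is a 26-fold lower number from compound 1 to compound 2 (1.41 log units; beyond the scatter).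

Compound 3 `O=C(Nc1c(C(O)(C(F)(F)F)C(F)(F)F)ccc2ccccc12)c1ccc(F)cc1` differs from compound 2 by 4-fluorophenyl in place of 3-bromophenyl on a carbonyl carbon. Among the measured compounds shown here, the one measured step, a 26-fold lower number from compound 1 to compound 2 (1.41 log units; beyond the scatter), changes halogen and ring position together and therefore bears on this change only indirectly; no measured pair isolates either halogen identity or position alone. A moderate rise in the number is expected, with wide uncertainty.

For compound 3 in this assay the estimate is 300 nM, range 60 nM to 1500 nM, which is expected to correspond to a 3.8-fold higher number from compound 2 to compound 3 (0.57 log units; beyond the scatter).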

Compound 3, half-maximal effective concentration: 70 nM
Estimate against measurement, compound 3: 4.3-fold (0.63 log units) above; measured number inside the range.
By their numbers in this assay, from the lowest: compounds 3 and 2 (each within the scatter of the next); then compound 1.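

In this assay a change of both halogen and ring position, 4-fluorophenyl for 3-bromophenyl, gives a 1.1-fold lower number from compound 2 to compound 3 (0.06 log units; within the scatter), so this position tolerates two different halogen-bearing phenyl groups with no readable difference. The gap to the 2-chlorophenyl remains large, at a 29-fold lower number from compound 1 to compound 3 (1.46 log units; beyond the scatter), which leaves compound 1 alone apart from compound 2 and compound 3. No evidence on a cause is available.

Whether halogen identity or ring position accounts for the gap to compound 1 stays open, since no pair separates them. Equally open, going by these compounds, is how a plain phenyl, or a phenyl carrying an amine or a carboxylic acid, would read at this position.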